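Fluorophenyl placement on the shared core: compound 1 to compound 4

A few compounds are considered here, and "the series" means these few. Any claim that something is new, unique, unknown or untested is made for them only; others in the source may bear on it.

Measured so far in an assay on isolated protein for inhibition of prostaglandin G/H synthase 1 (Mus musculus), tested at 10 ug/mL; a higher number here means more inhibition at the concentration tested (going by the name of the read-out), a lower number less inhibition:
compound 1 `CS(=O)(=O)c1ccc(-c2oc3ccccc3c(=O)c2-c2ccc(F)cc2)cc1`: < 8%
compound 2 `NS(=O)(=O)c1ccc(-c2oc3ccccc3c(=O)c2-c2ccccc2)cc1`: 61%
compound 3 `COc1ccc(-c2c(-c3ccc(S(C)(=O)=O)cc3)oc3ccccc3c2=S)cc1`: < 5%

In this assay compound 1 gives only a limit, (the limit of < 8% in this assay, at which 1 of the 3 values shown sits), not a number. Compound 3 likewise sits at a limit, (the limit of < 5% in this assay, at which 1 of the 3 values shown sits). Within the data shown here, compound 2 is the single numeric value in this assay and reads 61%. Among the measured compounds shown here, no two measured compounds differ in one place, so no measured step is available for calibration. Compound 4 `CS(=O)(=O)c1ccc(-c2oc3ccccc3c(=O)c2-c2cccc(F)c2)cc1` differs from compound 1 by 3-fluorophenyl in place of 4-fluorophenyl on an aromatic carbon. For the measured compounds named here, the two have the same atoms joined differently, and with no comparable step measured, the expected step of a number at least 2 percentage points higher from compound 1 to compound 4 (that floor lies within the scatter) is none beyond the scatter. Compound 4 is therefore estimated at 10%, range 0% to 30%, with a fair chance that this assay again returns only a limit.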

Compound 4, a percentage reported as inhibition, at one concentration (the size of the read-out at that concentration, not a potency): < 5%
Compound 4: a limit, no number (the forecaster's own chance of this, stated with the estimate: 50%); middle value at least 5 percentage points away from the limit.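

Compound 1 and compound 4 both return only limits in this assay, and no step can be read between them. The compounds shown leave open whether 3-fluorophenyl in place of 4-fluorophenyl changes inhibition at all.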